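Thioether Benzamides: Replacing the Sulfur Aryl Group of Compound 1

The compounds below may be only part of what the source reports. "The series", "measured", "known", "first", "only" and "open" are said of these compounds alone.

Measured compounds:
compound 1 `COc1ccc(SCc2ccc(C(=O)Nc3ccccc3N)cc2)cc1`: 2170 nM
compound 2 `CC(C)(C)c1ccc(SCc2ccc(/C=C/C(=O)Nc3ccccc3N)cc2)cc1`: "not determined" (no result reported)
compound 3 `COc1ccc(SCc2ccc(C(=O)Nc3ccccc3N)cc2)cc1OC`: 3400 nM
compound 4 `Nc1ccccc1NC(=O)c1ccc(CSCCc2ccccc2)cc1`: to be measured

In a functional assay on SMMC-7721 cells (Homo sapiens) for antiproliferative activity, read by CCK-8 assay, with a stated time of 72 h (on this read-out higher numbers stand for weaker inhibition and lower numbers for stronger inhibition), compound 1 gives 2170 nM. Within the data shown here, compound 1 holds the lower of the two numbers in this assay, but the only neighbour, compound 3, differs by a 1.6-fold higher number from compound 1 to compound 3 (0.20 log units; within the scatter), so the two sit within the scatter of each other and no order is claimed. Compound 2 carries no number.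

Compound 4 differs from compound 1 on the sulfur: phenethyl in place of 4-methoxyphenyl on a sulfur. Among the measured compounds shown here, no measured step touches this position; the single step in the set, from compound 1 to compound 3, concerns a methoxy on an aromatic carbon of the same aryl group and stays within the scatter. The set therefore gives no direction for an exchange of the whole aryl group for a phenethyl chain, and the shared core with its amide and amino groups is unchanged.

The expectation for compound 4 is a step of a 1.2-fold higher number from compound 1 to compound 4 (0.06 log units; within the scatter), that is, a number close to that of compound 1 with a wide range. The estimate for compound 4 in this assay is 2500 nM, between 900 nM and 7000 nM.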

Compound 4, half-maximal inhibitory concentration: 4880 nM
Estimate against measurement, compound 4: 2.0-fold (0.29 log units) below; the measured number falls inside the stated range.
By their numbers in this assay, from the lowest: compounds 1, 3 and 4 (each within the scatter of the next, the first and the last beyond it).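

In this assay, among these compounds, the exchange on the sulfur gives the first step that lies beyond the scatter (a 2.2-fold higher number from compound 1 to compound 4 (0.35 log units; beyond the scatter)), whereas adding a methoxy to the aryl group of compound 1 stayed within it (a 1.6-fold higher number from compound 1 to compound 3 (0.20 log units; within the scatter)), so replacing the whole 4-methoxyphenyl group moves the number modestly towards weaker inhibition. The 4-methoxyphenyl and phenethyl groups have the same heavy-atom count and each holds one six-membered aromatic ring of carbon only, but they differ in composition and in hydrogen-bond acceptors, and this single step cannot separate the loss of the methoxy from the exchange of the aryl group for a chain. No measurement at hand gives an explanation for the step.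

On these data alone, it remains open whether a benzyl group, a longer chain such as phenylpropyl, or a phenethyl group carrying a methoxy on its ring would give a number closer to that of compound 1 or compound 4. Also open, as far as these compounds go, is how a chain ending in an amine or a carboxylic acid in place of the phenyl ring would behave on this sulfur.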